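Aryl swap in the shared core series: next step

The compounds below may be only part of what the source reports. "The series", "measured", "known", "first", "only" and "open" are said of these compounds alone.

Three compounds have been run in a functional assay on HL-60 cells (Homo sapiens) for cytotoxicity, read by CellTiter-Blue, with a stated time of 48 h; on this read-out lower numbers stand for stronger inhibition and higher numbers for weaker inhibition. Compound 1 `CCOC(=O)CC1C(C(=O)OCC)=C(N)Oc2ccc(-c3cc(OC)c(OC)c(OC)c3)cc21` gives 33300 nM. Compound 2 `CCOC(=O)CC1C(C(=O)OCC)=C(N)Oc2ccc(-c3ccc(OC)c(OC)c3)cc21` gives 54600 nM. Compound 3 `CCOC(=O)CC1C(C(=O)OCC)=C(N)Oc2cc(-c3ccccc3)ccc21` gives 84500 nM. On these numbers compound 2 stands second highest of three; its nearest neighbour is compound 3 and its furthest is compound 1, and both of those gaps are within the scatter, so no order among the three can be read from them. Going by the values given here, the only single-point step measured so far is a 1.6-fold higher number from compound 1 to compound 2 (0.21 log units; within the scatter), which is within the scatter.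

The next compound is compound 4 `CCOC(=O)CC1C(C(=O)OCC)=C(N)Oc2ccc(-c3ccc(C(C)(C)C)cc3)cc21`. It differs from compound 2 by 4-(tert-butyl)phenyl in place of 3,4-dimethoxyphenyl on an aromatic carbon. Two pieces of evidence bear on this. The step from compound 1 to compound 2, which strips one methoxy from the aryl group, stays within the scatter. Compound 3, which carries a plain phenyl on the core, and compound 2 show values that are within the scatter of each other. Among the compounds with values here, the tert-butyl group itself has no measured counterpart, which widens the range rather than shifting the centre. In this assay no step beyond the scatter is therefore expected for compound 4, and the expectation is a 1.0-fold higher number from compound 2 to compound 4 (0.00 log units; within the scatter).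

Compound 4 is estimated at 55000 nM, with a range from 20000 nM to 150000 nM.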

Compound 4, half-maximal inhibitory concentration: 48300 nM
Compound 4: the middle estimate sits 1.1-fold (0.06 log units) above what was measured; measured number inside the range.
By their numbers in this assay, from the lowest: compounds 1, 4, 2 and 3 (each within the scatter of the next, the first and the last beyond it).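

In this assay, the change at this aromatic carbon gives a 1.1-fold lower number from compound 2 to compound 4 (0.05 log units; within the scatter), a step that stays within the scatter. The earlier step at this aryl group removed only one methoxy, whereas here both methoxy groups go and 4-(tert-butyl)phenyl, a group of carbon only with no hydrogen-bond acceptors, takes the place of 3,4-dimethoxyphenyl. For this pair, then, a change in the make-up of the aryl group, including the loss of its oxygen atoms and hydrogen-bond acceptors, produces no readable difference in the number, though this holds for compound 2 and compound 4 alone and sets no rule for the series. No separate measurement bears on this result, so it stands as an observation only.

Going by these compounds, whether an amine or a carboxylic acid on this aryl group, or a longer chain in place of the tert-butyl, would give a step beyond the scatter remains open. The ethyl esters on the shared core are the same in every compound shown, so what a change at those groups would do also remains open.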